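Replacing the Dimethylpiperazine of Compound 1

This account rests on a few compounds, and the source may have more. Where it says the series, first, only, none or still open, it means among the compounds named here.

In an ADME assay on microsomes from liver (Homo sapiens) for metabolic stability, read by LC-MS, with a stated time of 10 min (a lower number here means that less of the compound is left, a higher number that more of the compound is left), compound 1 (`C[C@@H]1CN(c2cccc3c2C[C@H](CN(C)[C@H]2CCCc4cccnc42)NC3)C[C@H](C)N1`) gives 100%, the highest of three numbers. Compound 2 (`CCN(C[C@H]1Cc2c(cccc2N2CCNCC2)CN1)[C@H]1CCCc2cccnc21`) gives 79.1% and compound 3 (`CC(C)N(C[C@H]1Cc2c(cccc2N2CCNCC2)CN1)[C@H]1CCCc2cccnc21`) gives 75%. Compound 4 (`CN1CCN(c2cccc3c2C[C@H](CN(C)[C@H]2CCCc4cccnc42)NC3)CC1`) differs from compound 1 by 4-methylpiperazin-1-yl in place of 3,5-dimethylpiperazin-1-yl on an aromatic carbon. Within the data shown here, the only measured step, a number 4.1 percentage points lower from compound 2 to compound 3 (within the scatter), lies elsewhere in the molecule, so no measured step covers this change directly. Compound 2 (79.1%) and compound 3 (75%) also lack the 3,5-dimethylpiperazin-1-yl group, so a moderate fall is expected. The expected change is a number 18 percentage points lower from compound 1 to compound 4 (beyond the scatter). Compound 4 is estimated at 82%, with an expected range from 65% to 98%.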

Compound 4, percent of the compound remaining: 75.8%
Estimate against measurement, compound 4: 6.2 percentage points above; measured number inside the range.
By their numbers in this assay, from the lowest: compounds 3, 4 and 2 (each within the scatter of the next); then compound 1.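

At this position, on an aromatic carbon of a six-membered aromatic ring of carbon only, this assay now gives a direct reading of 4-methylpiperazin-1-yl in place of 3,5-dimethylpiperazin-1-yl: a number 24.2 percentage points lower from compound 1 to compound 4 (beyond the scatter). Among these compounds, the only earlier step lay elsewhere in the molecule, so this is the first sign that the group at this position matters for the read-out. Nothing available explains the fall. Open, on these data alone, is where a morpholin-4-yl or a 3-methylpiperazin-1-yl group on the core of compound 1 would stand. Also open is which feature of the 3,5-dimethylpiperazin-1-yl group accounts for the difference.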